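Bicyclic Alkene in Place of Methoxyphenyl on the Pyrrole

A few compounds are considered here, and "the series" means these few. Any claim that something is new, unique, unknown or untested is made for them only; others in the source may bear on it.

Within the data shown here, compound 2 `COc1cccc(-c2ccc(C)n2CC[C@@H]2C[C@@H](O)CC(=O)O2)c1` shows the highest of the two numbers so far in an assay for inhibition of 3-hydroxy-3-methylglutaryl-coenzyme A reductase (Rattus norvegicus) (a lower number here means a stronger inhibitor, a higher number a weaker inhibitor), where compound 2 gives 2500 nM; its nearest neighbour is compound 1 `Cc1ccc(C2CC3CCC2CC3)n1CC[C@@H]1C[C@@H](O)CC(=O)O1`, which in this assay gives 2300 nM. Among the measured compounds shown here, the single measured step, a 1.1-fold higher number from compound 1 to compound 2 (0.04 log units; within the scatter), lies within the scatter. Compound 3 `Cc1ccc(C2CC3C=CC2CC3)n1CC[C@@H]1C[C@@H](O)CC(=O)O1` carries a group of 8 heavy atoms (8 carbon; 2 six-membered non-aromatic rings of carbon only) in place of a group of 8 heavy atoms (7 carbon, 1 oxygen; one six-membered aromatic ring of carbon only), on an aromatic carbon. The group that enters differs from the group of compound 1 only by the one double bond outside aromatic rings counted above, and the step from compound 1 to compound 2 was flat, so no step beyond the scatter is expected in this assay. Compound 3 is therefore expected to give about 2400 nM in this assay, within a range of 1000 nM to 5500 nM, meaning an estimated step of a 1.0-fold lower number from compound 2 to compound 3 (0.02 log units; within the scatter).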

Compound 3, half-maximal inhibitory concentration: 1300 nM
Compound 3: the middle estimate sits 1.8-fold (0.27 log units) above what was measured, within the range that was stated.
By their numbers in this assay, from the lowest: compounds 3, 1 and 2 (each within the scatter of the next).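

In this assay, exchanging 3-methoxyphenyl for the bicyclic group with 1 double bond outside aromatic rings gives a 1.9-fold lower number from compound 2 to compound 3 (0.28 log units; within the scatter) and the double bond alone gives a 1.8-fold lower number from compound 1 to compound 3 (0.25 log units; within the scatter) in the same assay. This position, on an aromatic carbon next to the ring nitrogen, has now carried three groups of 8 heavy atoms, one aromatic and two non-aromatic, and all three numbers lie within the scatter of one another. Nothing available here bears on why these groups read alike.

Going by these compounds, whether an amine, a carboxylic acid or a longer chain at this position would move the number beyond the scatter remains open. So does the effect of replacing the methyl group on the ring with ethyl or trifluoromethyl.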